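Swapping isobutyl for sec-butyl in a cell toxicity test

The source may report more compounds than this note shows. Statements on the series, on what has been measured and on what is new or still open speak of the compounds shown alone.

For the measured compounds named here, only two compounds have been tested so far in an ADME assay on A549 cells (Homo sapiens) for cytotoxicity, with a stated time of 72 h; on this read-out higher numbers stand for weaker inhibition and lower numbers for stronger inhibition. Compound 1 `COc1cc(NC(C)CCCN2C(=O)[C@@H](C)N(C(=O)CN)C2(C)C)c2ncccc2c1` reached only a limit of this test, > 100000 nM. Going by the values given here, compound 2 `COc1cc(NC(C)CCCN2C(=O)CN(C(=O)[C@H](N)CC(C)C)C2(C)C)c2ncccc2c1` gave an actual number, 21200 nM, and it is the only exact value available. Compound 3 `CC[C@H](C)[C@@H](N)C(=O)N1CC(=O)N(CCCC(C)Nc2cc(OC)cc3cccnc23)C1(C)C` has the same atoms as compound 2, joined differently: sec-butyl in place of isobutyl on a saturated chain carbon bound to an amine nitrogen and a carbonyl carbon. Put simply, sec-butyl stands in place of isobutyl on a saturated chain carbon bound to an amine nitrogen and a carbonyl carbon. Among the compounds with values here, no tested pair shows what this swap does, so the expectation rests on compound 2 at 21200 nM. The expected step of a 1.1-fold higher number from compound 2 to compound 3 (0.05 log units; within the scatter) is small, with no change beyond the usual scatter in either direction. Compound 3 is estimated at 24000 nM, with an expected range of 9000 nM to 60000 nM.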

Compound 3, half-maximal inhibitory concentration in the A549 assay: 14900 nM
Estimate against measurement, compound 3: 1.6-fold (0.21 log units) above, and the stated range covers the measured number.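

For the compounds shown here, this is the first pair in the A549 assay that differs in one place: sec-butyl stands in place of isobutyl on a saturated chain carbon bound to an amine nitrogen and a carbonyl carbon, giving a 1.4-fold lower number from compound 2 to compound 3 (0.15 log units; within the scatter). In the A549 assay compound 2 gives 21200 nM and compound 3 gives 14900 nM. In a physicochemical assay for lipophilicity, measured as octanol-water partition (a lower number here means a more polar compound, a higher number a more lipophilic compound), compound 2 gives 3.36 and compound 3 gives 3.4. In the physicochemical assay the same swap gives a number 0.04 log units higher from compound 2 to compound 3 (within the scatter), so for these two butyl chains, neither read-out separates the pair beyond the usual scatter. Compound 1 stays outside this comparison because its result is only a limit: the limit of > 100000 nM in the A549 assay, at which 1 of the 3 values shown sits.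

Still open, going by these compounds, is how a chain carrying a ring, such as benzyl, or one ending in an amine or a carboxylic acid would read at this place. Also open, on these data alone, is whether the opposite arrangement at the defined stereocentre of sec-butyl would read the same.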